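A few compounds are considered here, and "the series" means these few. Any claim that something is new, unique, unknown or untested is made for them only; others in the source may bear on it.

Working notes on the series. Among the measured compounds shown here, compound 1 `CC(C)(C)[C@H]1CC[C@H](N(C(=O)Nc2ccc(OC(F)(F)F)cc2)C2CCOc3cc(C(=O)Nc4nn[nH]n4)ccc32)CC1` is the only member with a result in a functional assay on CHO cells for antagonist activity at gastric inhibitory polypeptide receptor (Homo sapiens), read by cAMP accumulation; on this read-out lower numbers stand for stronger inhibition and higher numbers for weaker inhibition: compound 1 gives 117 nM. For the measured compounds named here, compound 2 `CC(C)(C)[C@H]1CC[C@H](N(C(=O)c2ccc(OC(F)(F)F)cc2)C2CCc3cc(C(=O)NCCC(=O)O)ccc32)CC1` has no number in this assay, the result there being recorded as "not determined" (no result reported), so compound 2 stands nowhere on the measured scale and no step from it can be counted. Compound 3 `CC(C)(C)[C@H]1CC[C@H](N(C(=O)Nc2cc(Cl)cc(Cl)c2)C2CCc3cc(C(=O)NCCC(=O)O)ccc32)CC1` differs from compound 2 in one place: (3,5-dichlorophenyl)amino in place of 4-(trifluoromethoxy)phenyl on a carbonyl carbon. Going by the values given here, since compound 2 gives no value in this assay, the size and direction of the step to compound 3 cannot be read from the data; the only anchor is compound 1, which shares the urea with compound 3 but differs from it elsewhere, so no pattern is claimed. The expectation for compound 3 in this assay is a value near that of compound 1, estimated at 150 nM with a range from 30 nM to 800 nM.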

Compound 3, half-maximal inhibitory concentration: 1280 nM
Compound 3: middle estimate off by 8.5-fold (0.93 log units), on the low side, and the stated range ends below it.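

No new step can be read: compound 3 has a value in this assay, but compound 2, its one-place neighbour, has none. The compounds shown leave open what (3,5-dichlorophenyl)amino in place of 4-(trifluoromethoxy)phenyl does to inhibition. No supporting evidence bears on this result.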